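Swapping a furan for a pyrazole on the thiazole-free core

The source may report more compounds than this note shows. Statements on the series, on what has been measured and on what is new or still open speak of the compounds shown alone.

Compound 1 `NS(=O)(=O)c1ccc(-c2nc(C(c3ccc(F)cc3)c3ccc(F)cc3)sc2CC(=O)O)cc1` gives 1500 nM
Compound 2 `CS(=O)(=O)Nc1cccc(-c2nc(C(c3ccc(F)cc3)c3ccc(F)cc3)sc2CC(=O)O)c1` gives 40 nM
Compound 3 `O=C(O)Cc1sc(C(c2ccc(F)cc2)c2ccc(F)cc2)nc1-c1ccoc1` gives 14 nM

These three share one core and differ only in the ring attached to it. In an in vitro assay on HEK385-7 cells for displacement of a labelled ligand from prostaglandin D2 receptor 2 (Homo sapiens) (on this read-out higher numbers stand for weaker inhibition and lower numbers for stronger inhibition), compound 3 stands lowest of the three numbers: the nearest is compound 2, and the step of a 2.9-fold lower number from compound 2 to compound 3 (0.46 log units; beyond the scatter) is modest, while the step of a 110-fold lower number from compound 1 to compound 3 (2.03 log units; beyond the scatter) is large. Compound 4 `O=C(O)Cc1sc(C(c2ccc(F)cc2)c2ccc(F)cc2)nc1-c1cn[nH]c1` is not yet measured. It differs from compound 3 by 1H-pyrazol-4-yl in place of furan-3-yl on an aromatic carbon. Going by the values given here, no measured step exchanges one small ring for another of this kind, so the bearing of the earlier steps is indirect: they show that the 4-sulfamoylphenyl group gives the highest number of the three, through the steps of a 38-fold lower number from compound 1 to compound 2 (1.57 log units; beyond the scatter) and a 110-fold lower number from compound 1 to compound 3 (2.03 log units; beyond the scatter). A ring of the same size as furan-3-yl is therefore expected to sit close to compound 3, with no step beyond the scatter and perhaps a slight rise. For compound 4 the estimate in this assay is 20 nM, within 6 nM to 70 nM, meaning an expected step of a 1.4-fold higher number from compound 3 to compound 4 (0.15 log units; within the scatter).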

Compound 4, half-maximal inhibitory concentration: 16 nM
Compound 4: middle estimate off by 1.3-fold (0.10 log units), on the high side; low and high end bracket the measured number.
By their numbers in this assay, from the lowest: compounds 3 and 4 (each within the scatter of the next); then compound 2; then compound 1.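

In this assay, the step of a 1.1-fold higher number from compound 3 to compound 4 (0.06 log units; within the scatter) shows that this position, on the carbon next to the ring nitrogen, takes a second five-membered aromatic ring with 2 hetero atoms and 1 hydrogen-bond donor, with no change beyond the scatter. The 1H-pyrazol-4-yl group also keeps the advantage seen for furan-3-yl over the two substituted phenyl groups, with a 2.5-fold lower number from compound 2 to compound 4 (0.40 log units; beyond the scatter) being modest and a 94-fold lower number from compound 1 to compound 4 (1.97 log units; beyond the scatter) being large. Nothing measured here explains why the two small rings give such similar numbers.

On these data alone, it remains open whether the hydrogen on the pyrazole nitrogen matters at all, which a 1-methylpyrazol-4-yl group could test. An unsubstituted phenyl or a thiophene ring at this position would show whether the hetero atoms of the small ring are needed.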